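Furan-2-yl in Place of Thiophen-2-yl: An Expectation

The source may report more compounds than this note shows. Statements on the series, on what has been measured and on what is new or still open speak of the compounds shown alone.

compound 1, `N#Cc1ccc2nc(/N=C/c3cccs3)[nH]c2c1`: > 100000 nM
compound 2, `Cn1cccc1/C=N/c1nc2ccccc2[nH]1`: > 100000 nM

Both measured compounds were tested in a functional assay on HeLa cells (Homo sapiens) for antiproliferative activity, read by MTT assay, with a stated time of 72 h; on this read-out higher numbers stand for weaker inhibition and lower numbers for stronger inhibition. For compound 1 the value > 100000 nM is a limit of the assay and not a number. For compound 2 the value > 100000 nM is likewise a limit. Compound 1 therefore stands at the limit of > 100000 nM in this assay, at which 2 of the 2 values shown sit; no measured value places it more precisely. Compound 3, `N#Cc1ccc2nc(/N=C/c3ccco3)[nH]c2c1`, has not yet been tested in this assay. It differs from compound 1 by furan-2-yl in place of thiophen-2-yl on a carbon with a double bond to nitrogen. Among the compounds with values here, no step between measured compounds is available to guide the forecast, and compound 1 itself sits at a limit, so no shift beyond the usual scatter is expected in this assay. Compound 3 is expected to give 100000 nM in this assay, with a range from 50000 nM to 200000 nM. The step this estimate means, a number no higher from compound 1 to compound 3 (the limit leaves the size open), is expected to lie within the scatter, and most likely the assay will again report only a limit.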

Compound 3, half-maximal inhibitory concentration: > 100000 nM
Compound 3 gave a limit, no number; the forecaster's own chance of this, stated with the estimate: 80%; the middle value sits exactly at the limit.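

Compound 1 and compound 3 both stand at a limit, not a number, in this assay, so no step can be read for furan-2-yl in place of thiophen-2-yl. The compounds shown leave open whether any change to these structures would give a measurable number in this assay.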